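The compounds below may be only part of what the source reports. "The series", "measured", "known", "first", "only" and "open" are said of these compounds alone.

Compound 1 `C=C[C@@](C)(/C=C/c1ccc(OCc2cn(-c3ccc(F)cc3)nn2)cc1)CCC=C(C)C` and compound 2 `C=C[C@@](C)(/C=C/c1ccc(OCc2cn(-c3ccc(C)cc3)nn2)cc1)CCC=C(C)C` share one core and differ at a single aromatic carbon of the outer ring. In a toxicity assay on RAW264.7 cells (Mus musculus) for cytotoxicity, read by MTT assay, with a stated time of 24 h (on this read-out higher numbers stand for weaker inhibition and lower numbers for stronger inhibition), compound 1 gives 233000 nM, and compound 2 gives 86900 nM. The change between them, (methyl in place of fluoro on an aromatic carbon), produced a 2.7-fold lower number from compound 1 to compound 2 (0.43 log units; beyond the scatter). Compound 3 `C=C[C@@](C)(/C=C/c1ccc(OC(=O)c2cn(-c3ccc(F)cc3)nn2)cc1)CCC=C(C)C` keeps the fluoro group but sits on a second core; the difference between the two cores is not broken down here. In this assay compound 3 gives 79900 nM, which against compound 2 lies within the scatter and against compound 1 is a lower number beyond it. Compound 4 `C=C[C@@](C)(/C=C/c1ccc(OC(=O)c2cn(-c3ccc(C)cc3)nn2)cc1)CCC=C(C)C` has not yet been run in this assay. It differs from compound 3 by methyl in place of fluoro on an aromatic carbon, at the same place as in the first pair, para to a large group, so this is the same change repeated on the second core. The expected step is a 2.0-fold lower number from compound 3 to compound 4 (0.30 log units; within the scatter). Among the measured compounds shown here, that expectation is tempered because a 2.7-fold lower number from compound 1 to compound 2 (0.43 log units; beyond the scatter) is the only measured instance of the change, and a step seen once may not transfer in full to a second core. For compound 4 in this assay the estimate is 40000 nM, with a range of 15000 nM to 110000 nM.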

Compound 4, half-maximal inhibitory concentration: 37200 nM
Estimate against measurement, compound 4: 1.1-fold (0.03 log units) above, within the range that was stated.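

In this assay, the change from 4-fluorophenyl to 4-methylphenyl on the second core gives a 2.1-fold lower number from compound 3 to compound 4 (0.33 log units; beyond the scatter), in the same direction as on the first core. The two steps cannot be told apart in size: the same change on two cores in this assay, a 2.7-fold lower number (0.43 log units; beyond the scatter) from compound 1 to compound 2 and a 2.1-fold lower number (0.33 log units; beyond the scatter) from compound 3 to compound 4, 1.2-fold (0.10 log units) apart, within the scatter of two such steps. In this series and this read-out, the change therefore carries from one core to the other with its direction and approximate size intact, but this rests on a single pair per core and shows nothing about further cores, other cell types or what produces the step.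

The compounds shown leave open whether the trend extends to other groups at the same place on the outer ring, such as chloro, methoxy, trifluoromethyl, an amine or a longer alkyl chain. Also open, on these data alone, is whether the same change behaves alike on a core carrying an amide in place of the ester.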